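Swapping the phenyl for a hexyl chain on sulfur

A few compounds are considered here, and "the series" means these few. Any claim that something is new, unique, unknown or untested is made for them only; others in the source may bear on it.

Compound 3 `CC(C)c1cccc(C(C)C)c1OC(=O)NC(=O)SCCc1ccccc1` is the weakest of the three measured compounds in an assay on microsomes from intestine for inhibition of acyl-CoA:cholesterol acyltransferase (Oryctolagus cuniculus) (a lower number here means a stronger inhibitor, a higher number a weaker inhibitor), giving 880 nM. Compound 1 `CCCCCCOC(=O)NC(=O)Oc1c(C(C)C)cccc1C(C)C` gives 53 nM and compound 2 `CCCCCCCCOC(=O)NC(=O)Oc1c(C(C)C)cccc1C(C)C` gives 250 nM. Compound 4 `CCCCCCCCSC(=O)NC(=O)Oc1c(C(C)C)cccc1C(C)C` differs from compound 3 by hexyl in place of phenyl on a saturated chain carbon, two bonds along the chain from a sulfur. For the measured compounds named here, two measured steps bear on this change. The step of a 3.5-fold higher number from compound 2 to compound 3 (0.55 log units; beyond the scatter) shows that putting phenethylsulfanyl in place of octyloxy weakened inhibition; compound 4 keeps the sulfur but restores the octyl chain, so much of that loss should be recovered. The step of a 4.7-fold higher number from compound 1 to compound 2 (0.67 log units; beyond the scatter) shows that the longer chain on its own also weakened inhibition, so no return to the level of compound 1 is expected. Compound 4 is therefore expected to give a modestly lower number than compound 3, a 2.9-fold lower number from compound 3 to compound 4 (0.47 log units; beyond the scatter), with an estimate of 300 nM and a range of 100 nM to 900 nM.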

Compound 4, half-maximal inhibitory concentration: 160 nM
The estimate for compound 4 lay 1.9-fold (0.27 log units) above the measured number, and the stated range covers the measured number.
By their numbers in this assay, from the lowest: compound 1; then compounds 4 and 2 (each within the scatter of the next); then compound 3.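

In this assay, the step of a 5.5-fold lower number from compound 3 to compound 4 (0.74 log units; beyond the scatter) shows that on this sulfur chain an octyl end serves far better than a phenethyl end. The sulfur itself makes no distinguishable difference, as the step of a 1.6-fold lower number from compound 2 to compound 4 (0.19 log units; within the scatter) stays within the scatter. Compound 1 still holds its lead, with the step of a 3.0-fold higher number from compound 1 to compound 4 (0.48 log units; beyond the scatter). No supporting data explain these differences. The compounds shown leave open whether a hexylsulfanyl chain would match the hexyloxy chain of compound 1, and whether an amine at the chain end would be tolerated.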